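Thiazole substituent change across two indazole acid cores

This account rests on a few compounds, and the source may have more. Where it says the series, first, only, none or still open, it means among the compounds named here.

Measured:
compound 1 `Cc1csc(-c2cccc(CN(C)c3ccc4[nH]nc(C(=O)O)c4c3)c2)n1`: 650 nM
compound 2 `Cc1csc(-c2cccc(CNc3ccc4[nH]nc(C(=O)O)c4c3)c2O)n1`: 23 nM
compound 3 `CC(C)c1csc(-c2cccc(CNc3ccc4[nH]nc(C(=O)O)c4c3)c2O)n1`: 65 nM

All three were tested in an assay on isolated protein for inhibition of 2-Hydroxyacid oxidase 1 (Homo sapiens), with stated times of 30 min and 15 min; a lower number here means a stronger inhibitor, a higher number a weaker inhibitor. Compound 2 gives 23 nM and compound 3 gives 65 nM; the change between them is isopropyl in place of methyl on an aromatic carbon, and it gave a 2.8-fold higher number from compound 2 to compound 3 (0.45 log units; beyond the scatter). Compound 1 gives 650 nM; the difference between its core and that of compound 2 is not broken down here.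

Compound 4 `CC(C)c1csc(-c2cccc(CN(C)c3ccc4[nH]nc(C(=O)O)c4c3)c2)n1` has not yet been measured. It differs from compound 1 by isopropyl in place of methyl on an aromatic carbon, the same change as that from compound 2 to compound 3. The step from compound 1 to compound 4 in this assay is expected to be about a 2.8-fold higher number from compound 1 to compound 4 (0.44 log units; beyond the scatter), because the same change gave a 2.8-fold higher number from compound 2 to compound 3 (0.45 log units; beyond the scatter); it rests on one pair only. Compound 4 is estimated at 1800 nM, with a range from 700 nM to 4500 nM.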

Compound 4, half-maximal inhibitory concentration: 710 nM
Beside the measured number, compound 4's estimate is 2.5-fold (0.40 log units) above it, and the stated range covers the measured number.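

In this assay, the change from 4-methyl-1,3-thiazol-2-yl to 4-isopropyl-1,3-thiazol-2-yl gives a 1.1-fold higher number from compound 1 to compound 4 (0.04 log units; within the scatter), so on the core of compound 1 the step cannot be told from no change. Set beside the earlier step, the two cores do not separate: the same change on two cores in this assay, a 2.8-fold higher number (0.45 log units; beyond the scatter) from compound 2 to compound 3 and a 1.1-fold higher number (0.04 log units; within the scatter) from compound 1 to compound 4, 2.6-fold (0.41 log units) apart, within the scatter of two such steps. With one pair per core, this shows neither that the change carries over at the same size nor that the two cores respond differently.

Open, from the compounds shown here alone, is how ethyl or cyclopropyl at the same place would read on either core. The two cores differ in both the hydroxyl and the methyl on the amine nitrogen, and no compound shown separates these two differences.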